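Cytotoxicity limits in three analogues and a fourth expected

A few compounds are considered here, and "the series" means these few. Any claim that something is new, unique, unknown or untested is made for them only; others in the source may bear on it.

Measured so far in an ADME assay on HepG2 cells (Homo sapiens) for cytotoxicity, read by CellTiter-Glo and resazurin assay, with a stated time of 72 h; a higher number here means that more compound is needed for the effect, a lower number that less compound is needed:
Compound 1 `CC(=O)c1cccc(-c2ccc(C(=O)N(Cc3cccc(OCCCCCC(=O)O)c3)C(C)C)cc2)c1` gives > 26000 nM, which is a limit of the assay.
Compound 2 `CC(C)N(Cc1cccc(OCCCCCC(=O)O)c1)C(=O)c1ccc(-c2cccc(Oc3ccccc3)c2)cc1` gives > 18700 nM, which is a limit of the assay.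
Compound 3 `Cc1nnc(-c2cccc(-c3ccc(C(=O)N(Cc4cccc(OCCCCCC(=O)O)c4)C(C)C)cc3)c2)o1` gives > 26000 nM, which is a limit of the assay.

Compound 3 therefore stands at a limit, not at a number, in this assay. It sits at the limit of > 26000 nM in this assay, at which 2 of the 3 values shown sit, together with compound 1, while compound 2 sits at the limit of > 18700 nM in this assay, at which 1 of the 3 values shown sits. None of the three steps among them can be read: a step that the two limits leave unreadable from compound 1 to compound 2, a step that the two limits leave unreadable from compound 1 to compound 3 and a step that the two limits leave unreadable from compound 2 to compound 3 are all hidden by the two limits.

Compound 4 `CCOc1cccc(-c2ccc(C(=O)N(Cc3cccc(OCCCCCC(=O)O)c3)C(C)C)cc2)c1` is not yet measured. It differs from compound 3 in one place: ethoxy in place of 5-methyl-1,3,4-oxadiazol-2-yl on an aromatic carbon. Going by the values given here, no measured step bears on this change directly, and the steps that come closest, a step that the two limits leave unreadable from compound 1 to compound 3 and a step that the two limits leave unreadable from compound 2 to compound 3, are unreadable. In this assay the expectation for compound 4 is therefore no readable step at all, a step that the limit leaves unreadable from compound 3 to compound 4, since every measured neighbour sits at a limit. Compound 4 is estimated to give 30000 nM, with a range from 10000 nM to 100000 nM, and most likely only a limit will be reported.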

Compound 4, half-maximal effective concentration: > 20800 nM
Compound 4: no number, only a limit; the forecaster's own chance of this, stated with the estimate: 80%; the middle value does not contradict the limit.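

In this assay compound 4 gives > 20800 nM, which is a limit of the assay. Going by these compounds alone, compound 1, compound 2, compound 3 and compound 4 all stand at limits, so no step linking compound 4 to the others can be read. The compounds shown leave open whether acetyl, phenoxy, 5-methyl-1,3,4-oxadiazol-2-yl and ethoxy differ at all in this assay.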